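Methylamino to ethylamino on the shared core

A few compounds are considered here, and "the series" means these few. Any claim that something is new, unique, unknown or untested is made for them only; others in the source may bear on it.

In a functional assay on MCF7 cells (Homo sapiens) for antiproliferative activity, read by MTT assay, with a stated time of 48 h (a higher number here means a weaker inhibitor, a lower number a stronger inhibitor), compound 2 `COc1ccc(C(=O)c2cc(OC)c(OC)c(OC)c2)c(NC(=O)CO)c1` gives 230 nM, compound 3 `CNCC(=O)Nc1cc(OC)ccc1C(=O)c1cc(OC)c(OC)c(OC)c1` gives 550 nM and compound 1 `CCNCC(=O)Nc1cc(OC)ccc1C(=O)c1ccc(OC)c2c1C=CC(C)(C)O2` gives 7230 nM. Compound 3 therefore holds the second highest of the three numbers, beyond the scatter from both other compounds. Compound 4 `CCNCC(=O)Nc1cc(OC)ccc1C(=O)c1cc(OC)c(OC)c(OC)c1` differs from compound 3 as follows: methyl in place of hydrogen on a saturated chain carbon bound to an amine nitrogen. This is methyl in place of hydrogen on a saturated chain carbon bound to an amine nitrogen, so methylamino becomes ethylamino. For the measured compounds named here, the only measured single-place step at this chain is a 2.4-fold higher number from compound 2 to compound 3 (0.38 log units; beyond the scatter). That step is modest, and it is a different change, methylamino in place of hydroxy. Going by the values given here, no measured pair isolates the added methyl. Compound 1 also carries ethylamino, but on a different core, so its 7230 nM supports the direction only weakly. The expected step is a 1.5-fold higher number from compound 3 to compound 4 (0.16 log units; within the scatter), a modest rise in the number in this assay. Compound 4 is estimated at 800 nM, with an expected range from 300 nM to 2200 nM.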

Compound 4, half-maximal inhibitory concentration: 1050 nM
Estimate against measurement, compound 4: 1.3-fold (0.12 log units) below; low and high end bracket the measured number.
By their numbers in this assay, from the lowest: compound 2; then compounds 3 and 4 (each within the scatter of the next); then compound 1.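

With a 1.9-fold higher number from compound 3 to compound 4 (0.28 log units; within the scatter) in this assay as the first direct read on the added methyl, methylamino and ethylamino are not separated at this saturated chain carbon bound to an amine nitrogen. Ethylamino in place of hydroxy gives a 4.6-fold higher number from compound 2 to compound 4 (0.66 log units; beyond the scatter) and so, like a 2.4-fold higher number from compound 2 to compound 3 (0.38 log units; beyond the scatter) for methylamino, stands beyond the scatter from the hydroxy of compound 2. No evidence is available that explains these steps.

Open, as far as these compounds go, is whether a longer chain on this amine, such as propylamino, would stand beyond the scatter from the ethylamino of compound 4. Also open, from the compounds shown here alone, is how a dimethylamino group, a morpholine or a carboxylic acid in this place would read against hydroxy on the shared core.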